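The source may report more compounds than this note shows. Statements on the series, on what has been measured and on what is new or still open speak of the compounds shown alone.

Measured so far in a functional assay on SiHa cells (Homo sapiens) for inhibition, read by sulforhodamine B assay; on this read-out higher numbers stand for weaker inhibition of growth and lower numbers for stronger inhibition of growth:
- compound 1 `c1ccc(-c2ccc(-c3ccc(-c4nc5ccccc5[nH]4)cc3)cc2)cc1` gives 100000 nM
- compound 2 `Cc1ccc2[nH]c(-c3ccc(-c4ccc(-c5cccc(Cl)c5)cc4)cc3)nc2c1` gives 3600 nM
- compound 3 `COc1ccc(-c2ccc(-c3ccc(-c4nc5cc(C)ccc5[nH]4)cc3)cc2)cc1OC` gives 3510 nM

Compound 1 stands highest of the three, beyond the scatter from both compound 2 and compound 3, so it is the weakest growth inhibitor in this small set. Compound 4 `Oc1ccc(-c2ccc(-c3ccc(-c4nc5ccccc5[nH]4)cc3)cc2)cc1` is still unmeasured. It carries hydroxy in place of hydrogen on an aromatic carbon, para to a large group, turning phenyl into 4-hydroxyphenyl: hydroxy in place of hydrogen on an aromatic carbon.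

Among the measured compounds shown here, no measured step shows this change directly. The only one that bears on it, a 1.0-fold lower number from compound 2 to compound 3 (0.01 log units; within the scatter), puts 3,4-dimethoxyphenyl in place of 3-chlorophenyl on an aromatic carbon and stays within the scatter. Compound 2 at 3600 nM and compound 3 at 3510 nM both differ from compound 1 in more than one place, so their values only loosely suggest that a substituent could lower the number. A single hydroxy is therefore expected to give a moderate drop, with a wide margin of doubt. The expected change is a 5.0-fold lower number from compound 1 to compound 4 (0.70 log units; beyond the scatter). For compound 4 the estimated value is 20000 nM, with an expected range from 3500 nM to 100000 nM.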

Compound 4, concentration for 50% growth inhibition: 33300 nM
Compound 4: middle estimate off by 1.7-fold (0.22 log units), on the low side, and the stated range covers the measured number.
By their numbers in this assay, from the lowest: compounds 3 and 2 (each within the scatter of the next); then compound 4; then compound 1.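

In this assay, among the compounds shown here, hydroxy in place of hydrogen on an aromatic carbon, para to a large group, gives a 3.0-fold lower number from compound 1 to compound 4 (0.48 log units; beyond the scatter) and so turning phenyl into 4-hydroxyphenyl provides the first direct reading of a single change at this position. The earlier compounds shown here could only hint at the effect of a substituent here, as compound 2 and compound 3 each differ from compound 1 in more than one place. This step shows that adding one hydroxy to the core of compound 1 is enough to move the number beyond the scatter, towards stronger inhibition of growth, although only modestly, and no measurement at hand accounts for the size or direction of the shift.

The compounds shown leave open how a methoxy group, an amine or a carboxylic acid on the same aromatic carbon would compare with hydroxy. They also leave open whether hydroxy would give a step of similar size in a compound that also carries the methyl group found in compound 2 and compound 3.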